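The source may hold more compounds than are shown below. What is called first, only, known or untested is meant among the compounds shown, and "the series" means these compounds.

Four compounds built on a common core were examined in a functional assay on MDA-MB-468 cells (Homo sapiens) for cytotoxicity, read by sulforhodamine B assay, with a stated time of 48 h; on this read-out lower numbers stand for stronger inhibition of growth and higher numbers for weaker inhibition of growth. Compound 1 `O=C1C(=O)N(CN2CCN(c3ccnc4cc(Cl)ccc34)CC2)c2cc(Br)ccc21` gives 35800 nM in this assay. Compound 2 `O=C1C(=O)N(CN2CCN(c3ccnc4cc(Cl)ccc34)CC2)c2ccccc21` gives 37900 nM in this assay. Compound 2 arises from compound 1 through a single change, (hydrogen in place of bromo on an aromatic carbon), and the step it made was a 1.1-fold higher number from compound 1 to compound 2 (0.02 log units; within the scatter). Compound 3 `NC(=S)N/N=C1/C(=O)N(CN2CCN(c3ccnc4cc(Cl)ccc34)CC2)c2cc(Br)ccc21` gives 11200 nM in this assay, the lowest of the three values; the difference between the core of compound 3 and the core of compound 1 is not broken down here. Compound 4 `NC(=S)N/N=C1/C(=O)N(CN2CCN(c3ccnc4cc(Cl)ccc34)CC2)c2ccccc21` has not yet been measured in this assay. Within the data shown here, it differs from compound 3 by hydrogen in place of bromo on an aromatic carbon, the same change, at the same place, as the one that turns compound 1 into compound 2. Because that earlier step was a 1.1-fold higher number from compound 1 to compound 2 (0.02 log units; within the scatter), the expected step from compound 3 to compound 4 is a 1.1-fold higher number from compound 3 to compound 4 (0.03 log units; within the scatter) in this assay. Compound 4 is therefore estimated at 12000 nM in this assay, with an expected range from 6000 nM to 24000 nM.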

Compound 4, concentration for 50% growth inhibition: 20600 nM
The estimate for compound 4 lay 1.7-fold (0.23 log units) below the measured number; the measured number falls inside the stated range.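

In this assay, putting hydrogen in place of bromo on the core of compound 3 gave a 1.8-fold higher number from compound 3 to compound 4 (0.26 log units; within the scatter), so this change left the number within the scatter here too. Set beside the same change on the core of compound 1, the two steps agree: the same change on two cores in this assay, a 1.1-fold higher number (0.02 log units; within the scatter) from compound 1 to compound 2 and a 1.8-fold higher number (0.26 log units; within the scatter) from compound 3 to compound 4, 1.7-fold (0.24 log units) apart, within the scatter of two such steps This shows that, across these two cores, removing the bromo has no effect on growth inhibition that can be told from the scatter, and the change carried over from one core to the other; it does not show that the same would hold on a third core, and two steps this small cannot reveal a modest difference between the cores.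

The compounds shown leave open what a fluoro, a methoxy or an amine would do on that aromatic carbon, as only bromo and hydrogen appear there. They also leave open whether the step would stay this small with a hydrazone or an oxime in place of the thiosemicarbazone group of compound 3.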